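Series notes: from compound 3 to compound 4

The source may report more compounds than this note shows. Statements on the series, on what has been measured and on what is new or still open speak of the compounds shown alone.

Three compounds share the core of compound 1 `CN1CCC(CCCn2c(COc3ccccc3)nc3c(OCCCN4CCCCC4)cccc32)CC1` and have been measured in an in vitro assay on AV12 cells for binding affinity to Neuropeptide Y receptor type 1 (Homo sapiens) (a higher number here means a weaker inhibitor, a lower number a stronger inhibitor), where compound 1 gives 1.62 nM. Compound 2 `c1ccc(OCc2nc3c(OCCCN4CCCCC4)cccc3n2CCCC2CCN(CCCN3CCCCC3)CC2)cc1` gives 0.106 nM, and compound 3 `C=CCN1CCC(CCCn2c(COc3ccccc3)nc3c(OCCCN4CCCCC4)cccc32)CC1` gives 1.63 nM. Compound 3 stands at the top of the three numbers, but its value and that of compound 1 sit within the scatter of each other; compound 2 lies well below, a 15-fold higher number from compound 2 to compound 3 (1.19 log units; beyond the scatter).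

Compound 4 `O=C(CCCN1CCC(CCCn2c(COc3ccccc3)nc3c(OCCCN4CCCCC4)cccc32)CC1)c1ccccc1` differs from compound 3 in one place: 2-benzoylethyl in place of vinyl on a saturated chain carbon bound to an amine nitrogen in a ring. The measured steps that bear on this change are those at the same position. a 1.0-fold higher number from compound 1 to compound 3 (0.00 log units; within the scatter) shows that vinyl in place of hydrogen moves nothing beyond the scatter. a 15-fold lower number from compound 1 to compound 2 (1.18 log units; beyond the scatter) and a 15-fold higher number from compound 2 to compound 3 (1.19 log units; beyond the scatter) show that a longer chain here can shift the number a great deal, yet in both steps the chain that enters or leaves carries a second amine nitrogen in a ring, which 2-benzoylethyl does not. Among the measured compounds shown here, no measured step contains a benzoyl group, so the direction of the step is uncertain. A modest lowering is expected, a 2.0-fold lower number from compound 3 to compound 4 (0.31 log units; beyond the scatter), with a wide range around it. The estimate for compound 4 is 0.8 nM, between 0.2 nM and 3.5 nM.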

Compound 4, inhibition constant: 0.132 nM
Compound 4: middle estimate off by 6.1-fold (0.78 log units), on the high side; measured number below the stated range.
By their numbers in this assay, from the lowest: compounds 2 and 4 (each within the scatter of the next); then compounds 1 and 3 (each within the scatter of the next).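

In this assay, 2-benzoylethyl in place of vinyl on a saturated chain carbon bound to an amine nitrogen in a ring gives a 12-fold lower number from compound 3 to compound 4 (1.09 log units; beyond the scatter), and in place of hydrogen it gives a 12-fold lower number from compound 1 to compound 4 (1.09 log units; beyond the scatter), so a large lowering at this position does not require a second amine nitrogen in a ring. Benzoyl in place of piperidin-1-yl gives a 1.2-fold higher number from compound 2 to compound 4 (0.10 log units; within the scatter), which leaves the chain ending in benzoyl and the chain ending in piperidin-1-yl indistinguishable here, while the small vinyl change stays at a 1.0-fold higher number from compound 1 to compound 3 (0.00 log units; within the scatter), so among these compounds only the two larger chains lower the number. No evidence at hand accounts for the close match of these two quite different chain ends.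

Going by these compounds, whether the lowering depends on the carbonyl, the phenyl ring or simply the chain remains open: a phenylalkyl chain without the carbonyl and a plain alkyl chain of similar reach would separate these. Also open, on these data alone, are how the number responds to a shorter or longer chain, and whether a carboxylic acid at the chain end would behave like benzoyl or piperidin-1-yl.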